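The compounds below may be only part of what the source reports. "The series", "measured", "known", "first", "only" and "open" are said of these compounds alone.

In a physicochemical assay for solubility, with a stated time of 3 days, at pH 7 (a higher number here means a more soluble compound, a lower number a less soluble compound), compound 1 (`NC(=O)c1ccc2[nH]c(-c3ccc(OCCCO)cc3)nc2c1`) gives 7000 nM as its reading. Compound 2 (`NC(=O)c1ccc2[nH]c(-c3ccc(OCC4CCNCC4)cc3)nc2c1`) gives > 400000 nM as a limit of the assay and not a number. The step of an at least 57-fold higher number from compound 1 to compound 2 (1.75 log units; beyond the scatter) is large and beyond the scatter. Compound 3 (`COc1ccc(CN2CCCCC2CCOc2ccc(-c3nc4cc(C(N)=O)ccc4[nH]3)cc2)cc1`) reads 84000 nM and so holds the higher of the two true numbers, clearly above compound 1 and beyond the scatter.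

Compound 4 (`CC(=O)N1CCCCC1CCOc1ccc(-c2nc3cc(C(N)=O)ccc3[nH]2)cc1`) carries acetyl in place of 4-methoxybenzyl on an amine nitrogen in a ring. Among the compounds with values here, no measured step touches that nitrogen, so only the step of an at least 57-fold higher number from compound 1 to compound 2 (1.75 log units; beyond the scatter) bears on it, and only loosely: it shows that a change in the side chain can move readings in this assay a long way. A moderate fall beyond the scatter is therefore expected, towards compound 1 at 7000 nM as the nearest true number, though the direction is far from certain. The expected step is a 3.4-fold lower number from compound 3 to compound 4 (0.53 log units; beyond the scatter) in this estimate. Compound 4 is estimated at 25000 nM with a range from 4000 nM to 150000 nM expected.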

Compound 4, solubility: 193000 nM
Estimate against measurement, compound 4: 7.7-fold (0.89 log units) below; the whole stated range lies below it.
By their numbers in this assay, from the lowest: compound 1; then compound 3; then compound 4. At a limit, above all of these: compound 2.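

In this assay, within the data shown here, acetyl in place of 4-methoxybenzyl on the amine nitrogen in the ring gives a 2.3-fold higher number from compound 3 to compound 4 (0.36 log units; beyond the scatter), the only measured change at this nitrogen, and it shows that the group here does shift the reading. The acetyl compound also stands well clear of the simple alcohol side chain, with a 28-fold higher number from compound 1 to compound 4 (1.44 log units; beyond the scatter). Compound 2 holds a limit and not a number, so an at least 2.0-fold lower number from compound 2 to compound 4 (0.31 log units; beyond the scatter) gives only a minimum size for that step: the limit of > 400000 nM in this assay, at which 1 of the 4 values shown sits.

Acetyl and 4-methoxybenzyl differ at once in heavy atoms, ring and double bond, and the compounds shown cannot say which of these matters. Also open, from the compounds shown here alone, is how a free amine, a plain benzyl or a longer acyl chain on this nitrogen would read.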